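Fluoro for methoxymethyl on the aryl ring of compound 1

The compounds below may be only part of what the source reports. "The series", "measured", "known", "first", "only" and "open" are said of these compounds alone.

Compound 1 `COCc1ccccc1C1Cc2nccn2C1` is the starting point of this account. In a functional assay on CHO cells for agonist activity at Alpha-1A adrenergic receptor (Homo sapiens), read by FLIPR and calcium flux (on this read-out lower numbers stand for an effect already at smaller amounts and higher numbers for an effect only at larger amounts of compound), compound 1 gives 82 nM, which is the only single number shown here, the one further entry being a compound with several readings rather than a single value. That compound is compound 2 `c1ccc(C2CCc3nc[nH]c3C2)cc1`, which in this assay gives 234 nM; 123 nM; 315 nM (3 entries); these several readings, (the several entries of compound 2 in this assay, 234 nM; 123 nM; 315 nM (3 entries)), show the spread that repeated measurements of this kind can carry. Among the compounds with values here, no pair of measured compounds differs in only one place, so no measured step is available to lean on.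

The compound not yet measured is compound 3 `Fc1ccccc1C1Cc2nccn2C1`. It differs from compound 1 by fluoro in place of methoxymethyl on an aromatic carbon, ortho to a group of 8 heavy atoms. Within the data shown here, with no measured step of this sort, the expectation in this assay is for a shift that stays within the scatter, or at most a modest weakening, since a small substituent replaces a larger one at the same aromatic carbon.

On that basis compound 3 is expected to give about 110 nM in this assay, with a likely range from 35 nM to 350 nM, which amounts to an estimated step of a 1.3-fold higher number from compound 1 to compound 3 (0.13 log units; within the scatter).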

Compound 3, half-maximal effective concentration: 42 nM
For compound 3 the middle estimate is 2.6-fold (0.42 log units) above the measured one; measured number inside the range.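

In this assay, within the data shown here, the exchange on the aromatic carbon gives a 2.0-fold lower number from compound 1 to compound 3 (0.29 log units; within the scatter), which is the first step in this account between compounds that differ in one place. It shows that, on this read-out, the methoxymethyl with its hydrogen-bond acceptor can give way to fluoro, ortho to a group of 8 heavy atoms, without a shift beyond the scatter, so neither the larger group nor its oxygen is required at this place for a value in this range. A step of this size also sits within what repeated readings of a single compound can span in this series: the several entries of compound 2 in this assay, 234 nM; 123 nM; 315 nM (3 entries).

Only methoxymethyl and fluoro are shown on this aromatic carbon, so it remains open whether the place is indifferent to its substituent in general or only to these two groups, and an amine, a carboxylic acid or a longer chain could behave quite differently there. Among these compounds, compound 2 differs from compound 1 and compound 3 in more than one place, so it offers no further step, and how the shared core itself contributes remains open too.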